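The source may hold more compounds than are shown below. What is called first, only, known or untested is meant among the compounds shown, and "the series" means these compounds.

Measured so far:
compound 1 `Cc1ccc(S(=O)(=O)/C(=C/c2ccc(C)s2)C(=O)c2ccc(Br)cc2)cc1`: 25000 nM
compound 2 `O=C(/C(=C\c1ccc(F)cc1F)S(=O)(=O)c1ccc(Cl)cc1)c1ccc(Br)cc1`: 25000 nM
compound 3 `Cc1ccc(S(=O)(=O)/C(=C/c2c(O)cc(O)cc2O)C(=O)c2ccc(Br)cc2)cc1`: > 100000 nM, a limit of the assay rather than a number

In a functional assay on DU-145 cells (Homo sapiens) for inhibition, read by trypan blue exclusion, with a stated time of 96 h (a higher number here means a weaker inhibitor of growth, a lower number a stronger inhibitor of growth), compound 3 gives only > 100000 nM, which is the limit of the assay and not a number. On the numbers shown it stands apart from compound 1, as an at least 4.0-fold higher number from compound 1 to compound 3 (0.60 log units; beyond the scatter) shows. Compound 4 `Cc1ccc(S(=O)(=O)/C(=C/c2ccc(F)cc2F)C(=O)c2ccc(Br)cc2)cc1` has not yet been measured. It differs from compound 3 in one place: 2,4-difluorophenyl in place of 2,4,6-trihydroxyphenyl on a double-bonded chain carbon bound to a double-bonded chain carbon. Going by the values given here, the one measured step that bears on this change is an at least 4.0-fold higher number from compound 1 to compound 3 (0.60 log units; beyond the scatter), which runs the other way and ends at the limit of > 100000 nM in this assay, at which 1 of the 3 values shown sits. Compound 2, which also carries a 2,4-difluorophenyl group at this place, gives 25000 nM. A drop of at least modest size is therefore expected, an at least 4.0-fold lower number from compound 3 to compound 4 (0.60 log units; beyond the scatter). Compound 4 is estimated at 25000 nM, within 8000 nM to 80000 nM.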

Compound 4, concentration for 50% growth inhibition: > 100000 nM
Compound 4: only a limit was reported (the forecaster's own chance of this, stated with the estimate: 15%); middle value at least 4.0-fold (0.60 log units) away from the limit.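

In this assay compound 4 gives > 100000 nM, a limit of the assay and not a number. The 2,4-difluorophenyl group thus gives a measurable value only alongside chloro, since methyl in place of chloro on an aromatic carbon gives an at least 4.0-fold higher number from compound 2 to compound 4 (0.60 log units; beyond the scatter), while with the methyl kept, 2,4-difluorophenyl in place of 5-methylthiophen-2-yl gives an at least 4.0-fold higher number from compound 1 to compound 4 (0.60 log units; beyond the scatter). The step between compound 3 and compound 4 cannot be read, as both are limits: the limit of > 100000 nM in this assay, at which 2 of the 4 values shown sit.

Still open, on these data alone, is how 5-methylthiophen-2-yl behaves alongside chloro. Also open, as far as these compounds go, is whether an amine in place of methyl on that aromatic carbon would restore growth inhibition.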